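The source may report more compounds than this note shows. Statements on the series, on what has been measured and on what is new or still open speak of the compounds shown alone.

Three measured members of the series share one core and differ only in one group on it. Compound 1 `CCOC(=O)CCCCCOc1cccc(CN(C(=O)c2ccc(-c3cccc(-c4ccccc4)c3)cc2)C(C)C)c1`, compound 2 `CCOC(=O)CCCCCOc1cccc(CN(C(=O)c2ccc(-c3cccc(OCC)c3)cc2)C(C)C)c1` and compound 3 `CCOC(=O)CCCCCOc1cccc(CN(C(=O)c2ccc(-c3ccc4c(c3)OCCO4)cc2)C(C)C)c1` have each been run in an ADME assay on HEK293 cells (Homo sapiens) for cytotoxicity, read by CellTiter-Glo and resazurin assay, with a stated time of 72 h; a higher number here means that more compound is needed for the effect, a lower number that less compound is needed. In this assay compound 1 gives only a limit, > 26000 nM. In this assay compound 2 likewise gives only a limit, > 22300 nM. In this assay compound 3 also gives only a limit, > 24400 nM. Compound 3 thus stands at a limit, and the two other values shown are limits as well. The steps a step that the two limits leave unreadable from compound 1 to compound 2, a step that the two limits leave unreadable from compound 1 to compound 3 and a step that the two limits leave unreadable from compound 2 to compound 3 are unreadable in size; they are bounded by the limit of > 22300 nM in this assay, at which 1 of the 3 values shown sits, the limit of > 24400 nM in this assay, at which 1 of the 3 values shown sits, and (the limit of > 26000 nM in this assay, at which 1 of the 3 values shown sits). Compound 4 `CCOC(=O)CCCCCOc1cccc(CN(C(=O)c2ccc(-c3cccc(O)c3)cc2)C(C)C)c1` differs from compound 3 by 3-hydroxyphenyl in place of 2,3-dihydro-1,4-benzodioxin-6-yl on an aromatic carbon. Going by the values given here, no measured step bears readably on this change, since every value in this assay is capped. The expected step is a step that the limit leaves unreadable from compound 3 to compound 4, none beyond the scatter in this assay. For compound 4 the estimate is 30000 nM, with a range from 10000 nM to 100000 nM.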

Compound 4, half-maximal effective concentration: > 26000 nM
Compound 4: no number, only a limit; the forecaster's own chance of this, stated with the estimate: 85%; the middle value lies beyond the limit too.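

In this assay compound 4 gives only a limit, as do compound 1, compound 2 and compound 3, so no step among these four compounds can be read. The compounds shown leave open whether the group changed on the shared core affects cytotoxicity at all.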